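The source may report more compounds than this note shows. Statements on the series, on what has been measured and on what is new or still open speak of the compounds shown alone.

Compound 1 `CC1=C([Se]CC(OC(=O)[C@@H](CO)NC(=O)OC(C)(C)C)C(=O)NC(C)(C)C)C(=O)c2ccccc2C1=O` and compound 2 `CC1=C([Se]CC(OC(=O)[C@@H](CO)NC(=O)OC(C)(C)C)C(=O)NCCCCCC(=O)OCc2ccccc2)C(=O)c2ccccc2C1=O` share the same core and the same selenium-bearing side chain, and differ only in the amide substituent at the far end of that chain. In an ADME assay on PHF cells (Homo sapiens) for cytotoxicity, read by MTT assay, with a stated time of 24 h (on this read-out lower numbers stand for stronger inhibition and higher numbers for weaker inhibition), compound 1 gives 7000 nM, the lowest of the two numbers recorded so far; compound 2 gives 27000 nM, a higher number that falls beyond the usual scatter of this kind of measurement. Going by the values given here, no pair of measured compounds differing in a single place is available, so no single-change step can be drawn from the data.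

Compound 3 `CC1=C([Se]CC(OC(=O)[C@@H](CSSC(C)(C)C)NC(=O)OC(C)(C)C)C(=O)NC(C)(C)C)C(=O)c2ccccc2C1=O` differs from compound 1 in one place: ((tert-butyl)sulfanyl)sulfanyl in place of hydroxy on a saturated chain carbon, two bonds along the chain from an amide-type nitrogen and a carbonyl carbon. Among the compounds with values here, with no measured single-change step as a guide, the reviewer expects the step from compound 1 to compound 3 to be a 1.4-fold lower number from compound 1 to compound 3 (0.15 log units; within the scatter), small and not clearly beyond the scatter. The reviewer accordingly estimates compound 3 in this assay at 5000 nM, with a range from 1500 nM to 16000 nM.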

Compound 3, half-maximal inhibitory concentration: 4000 nM
The estimate for compound 3 lay 1.3-fold (0.10 log units) above the measured number; the range from low to high includes it.
By their numbers in this assay, from the lowest: compounds 3 and 1 (each within the scatter of the next); then compound 2.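

In this assay the change shows a 1.8-fold lower number from compound 1 to compound 3 (0.24 log units; within the scatter) when hydroxy gives way to ((tert-butyl)sulfanyl)sulfanyl on this saturated chain carbon. This position thus takes a group of 6 heavy atoms and 0 hydrogen-bond donors in place of one with 1 heavy atom and 1 hydrogen-bond donor, without a shift that stands clear of the scatter. No supporting measurement speaks to the reason for this result.

The compounds shown leave open whether an amine or a carboxylic acid on this same carbon would also stay within the scatter. They also leave open whether ((tert-butyl)sulfanyl)sulfanyl would behave the same way alongside the longer amide substituent of compound 2.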